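N-Methylation of an Indole Hydrazide Series in Pancreatic Cancer Cells

The compounds below may be only part of what the source reports. "The series", "measured", "known", "first", "only" and "open" are said of these compounds alone.

Of the compounds shown here, three of a shared hydrazide scaffold have been tested in a functional assay on MIA PaCa-2 cells (Homo sapiens) for cytotoxicity; on this read-out higher numbers stand for weaker inhibition and lower numbers for stronger inhibition. Compound 1 `COc1ccc2c(c1)c(/C=N\NC(=O)c1cn(C)c3ccccc13)cn2Cc1ccc(Cl)cc1` gives 56400 nM in this assay, compound 2 `COc1ccc2c(c1)c(/C=N\NC(=O)c1c[nH]c3ccccc13)cn2Cc1ccc(Cl)cc1` gives 26700 nM, and compound 3 `COc1ccc(Cn2cc(/C=N\NC(=O)c3c[nH]c4ccccc34)c3ccc(F)cc32)cc1` gives 43300 nM. The numbers of compound 3 and compound 1 lie within the usual scatter of each other, as do those of compound 3 and compound 2, so no order among them can be read from these values alone.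

Compound 1 and compound 2 differ in one place, (methyl in place of hydrogen on an aromatic nitrogen). In this assay the step of a 2.1-fold higher number from compound 2 to compound 1 (0.32 log units; beyond the scatter) is modest but lies beyond the scatter, so methyl in place of hydrogen on an aromatic nitrogen weakened inhibition here.

Compound 4 `COc1ccc(Cn2cc(/C=N\NC(=O)c3cn(C)c4ccccc34)c3ccc(F)cc32)cc1` has not yet been measured. It stands to compound 3 as compound 1 stands to compound 2, with the difference (methyl in place of hydrogen on an aromatic nitrogen). The surroundings of the change are described in the same words for both pairs, so this is the same change, made a second time in the series. The difference between the cores of compound 2 and compound 3 is not broken down here.

Resting on the step from compound 2 to compound 1, compound 4 is expected to show a step of a 2.1-fold higher number from compound 3 to compound 4 (0.32 log units; beyond the scatter) in this assay, giving an estimated 90000 nM, with a range from 40000 nM to 200000 nM. Among the measured compounds shown here, whether the second occurrence of the change behaves like the first is what the measurement of compound 4 will show.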

Compound 4, half-maximal inhibitory concentration: 55800 nM
Compound 4: the middle estimate sits 1.6-fold (0.21 log units) above what was measured, and the stated range covers the measured number.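

In this assay, the step on the core of compound 3 is a 1.3-fold higher number from compound 3 to compound 4 (0.11 log units; within the scatter), so on this core the effect of the methyl cannot be told apart from the ordinary spread of repeated measurements. Set side by side, the two occurrences of the change do not differ by more than that spread allows: the same change on two cores in this assay, a 2.1-fold higher number (0.32 log units; beyond the scatter) from compound 2 to compound 1 and a 1.3-fold higher number (0.11 log units; within the scatter) from compound 3 to compound 4, 1.6-fold (0.21 log units) apart, within the scatter of two such steps. Among the compounds shown here, this means the results are compatible with the change carrying over from one core to the other, but it does not show that the step has the same size on both cores or that it is a real effect on the second core, as there are only two pairs and one of them stays within the scatter.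

From the compounds shown here alone, all four compounds carry either hydrogen or methyl on this nitrogen, so it remains open how a longer chain such as ethyl or propyl, or a chain ending in an amine or a carboxylic acid, would read in this assay. Going by these compounds, it also remains open what each of the differences between the cores of compound 2 and compound 3 contributes when changed alone.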